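Rearranging the amide-bearing bicycle in a sulfonyl benzylamide series

The source may report more compounds than this note shows. Statements on the series, on what has been measured and on what is new or still open speak of the compounds shown alone.

Measured compounds:
compound 1, `O=C(NCc1ccc(S(=O)(=O)c2cccc(F)c2)cc1)c1cc2cnccc2[nH]1`, which in an assay for inhibition of Nicotinamide phosphoribosyltransferase (Homo sapiens), read by mass spectrometry, with stated times of 15 min and 30 min (on this read-out lower numbers stand for stronger inhibition and higher numbers for weaker inhibition), gives 5 nM;
compound 2, `O=C(NCc1ccc(S(=O)(=O)c2cccc(C(F)(F)F)c2)cc1)c1cc2cnccc2[nH]1`, which in this assay gives 8 nM;
compound 3, `O=C(NCc1ccc(S(=O)(=O)c2ccc(F)c(F)c2)cc1)c1cc2cnccc2[nH]1`, which in this assay gives 10 nM.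

Among these three numbers compound 2 holds the second highest place, yet all three sit within the scatter of one another: a 1.6-fold higher number from compound 1 to compound 2 (0.20 log units; within the scatter), a 2.0-fold higher number from compound 1 to compound 3 (0.30 log units; within the scatter) and a 1.3-fold higher number from compound 2 to compound 3 (0.10 log units; within the scatter). The account now turns from compound 2 to compound 4, `O=C(NCc1ccc(S(=O)(=O)c2cccc(C(F)(F)F)c2)cc1)c1ccc2nccn2c1`, which is yet to be measured in this assay. The two share every atom, joined differently: a group of 9 heavy atoms (7 carbon, 2 nitrogen; one five-membered aromatic ring with 2 hetero atoms, one six-membered aromatic ring with 1 hetero atom) in place of a group of 9 heavy atoms (7 carbon, 2 nitrogen; one five-membered aromatic ring with 1 hetero atom, one six-membered aromatic ring with 1 hetero atom), on a carbonyl carbon. Going by the values given here, none of the measured steps touches this carbonyl-bound bicycle; each of them alters only the aryl group on the sulfonyl sulfur, and each stayed within the scatter. So there is no measured guidance for the change to compound 4, and the one group lost is the sole hydrogen-bond donor of the bicycle. On that basis a step beyond the scatter towards a higher number is expected, a 3.8-fold higher number from compound 2 to compound 4 (0.57 log units; beyond the scatter), with wide uncertainty. For compound 4 the estimate in this assay is 30 nM, expected to fall between 6 nM and 200 nM.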

Compound 4, half-maximal inhibitory concentration: 8 nM
Beside the measured number, compound 4's estimate is 3.8-fold (0.57 log units) above it; the range from low to high includes it.
By their numbers in this assay, from the lowest: compounds 1, 2, 4 and 3 (each within the scatter of the next).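

In this assay, going by these compounds alone, the carbonyl-bound bicycle tolerates this rearrangement, with no change at the digits printed from compound 2 to compound 4 (within the scatter); this is the first view of that position, as every earlier step altered only the aryl group on the sulfonyl sulfur. The change goes from 1 hydrogen-bond donor and 1 hydrogen-bond acceptor to 0 hydrogen-bond donors and 2 hydrogen-bond acceptors, so for this pair, a hydrogen-bond donor in the group on the carbonyl carbon is not needed for a number in this range. No measurement here accounts for the absence of a shift, and the result therefore stands without an explanation.

The rearranged bicycle appears only with the 3-(trifluoromethyl)phenyl group on the sulfonyl sulfur, so the compounds shown do not tell whether it would give similar numbers with the aryl groups of compound 1 and compound 3. They also leave open how far this tolerance extends, for instance to a bicycle that carries an added amine or carboxylic acid, or to a single pyridine ring on the carbonyl carbon.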